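The source may report more compounds than this note shows. Statements on the series, on what has been measured and on what is new or still open speak of the compounds shown alone.

Compound 3 `CCc1nnc(SCC(=O)c2ccccc2)n1N1C(=O)c2ccccc2C1=O` stands at the ceiling of the series. In a functional assay on HepG2 cells (Homo sapiens) for cytotoxicity, read by MTT assay, with a stated time of 48 h (a lower number here means a stronger inhibitor, a higher number a weaker inhibitor), compound 3 gives > 200000 nM, which is a limit of the assay rather than a number. Compound 2 `Cc1nnc(SCC(=O)c2ccccc2)n1N1C(=O)c2ccccc2C1=O` likewise gives only a limit in this assay, > 200000 nM. Compound 1 `CCOC(=O)CSc1nnc(C)n1N1C(=O)c2ccccc2C1=O` also gives a limit, > 200000 nM. The related steps, a step that the two limits leave unreadable from compound 1 to compound 2 and a step that the two limits leave unreadable from compound 2 to compound 3, are therefore unreadable, because of the limit of > 200000 nM in this assay, at which 3 of the 3 values shown sit. Compound 4 `CCOC(=O)CSc1nnc(CC)n1N1C(=O)c2ccccc2C1=O` differs from compound 3 by ethoxy in place of phenyl on a carbonyl carbon. The prior ethoxy-to-phenyl exchange left no readable step, so the expected step from compound 3 to compound 4 is estimated as a number no higher from compound 3 to compound 4 (the limit leaves the size open), with no change beyond the scatter. Compound 4 is expected at 200000 nM, range 100000 nM to 1000000 nM, most likely again only a limit.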

Compound 4, half-maximal inhibitory concentration: > 200000 nM
Compound 4 gave a limit, no number; the forecaster's own chance of this, stated with the estimate: 85%; the middle value lies on the limit itself.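

Compound 4 adds no readable step against compound 3 or compound 1 in this assay, because the values shown are all limits: the limit of > 200000 nM in this assay, at which 4 of the 4 values shown sit.

The compounds shown leave open what size, if any, the ethoxy-for-phenyl and methyl-for-hydrogen exchanges have.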